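Tetrazolyl quinolone series: bromo for trifluoromethyl

The compounds below may be only part of what the source reports. "The series", "measured", "known", "first", "only" and "open" are said of these compounds alone.

Measured so far:
compound 1 `O=C(O)c1cnc2cc(C(F)(F)F)ccc2c1`: > 25 mg/kg
compound 2 `O=c1c(-c2nn[nH]n2)c[nH]c2c(C(F)(F)F)cccc12`: 0.156 mg/kg

Two compounds have been run in a functional assay on the whole organism (strain Sprague-Dawley) for inhibition, with Rattus norvegicus as the target; a higher number here means that more compound is needed for the effect, a lower number that less compound is needed. Compound 1 `O=C(O)c1cnc2cc(C(F)(F)F)ccc2c1` reaches only a limit of the assay in this assay, > 25 mg/kg, and gives no number. Among the measured compounds shown here, compound 2 `O=c1c(-c2nn[nH]n2)c[nH]c2c(C(F)(F)F)cccc12` is the one compound with a real value, 0.156 mg/kg in this assay. Compound 2 therefore stands as the only number shown, with the remaining value being the limit (the limit of > 25 mg/kg in this assay, at which 1 of the 2 values shown sits). For the measured compounds named here, no pair of measured compounds differs in one place, so there is no measured step to lean on.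

Compound 3 `O=c1c(-c2nn[nH]n2)c[nH]c2c(Br)cccc12` is yet to be measured in this assay. Against compound 2 it carries bromo in place of trifluoromethyl on an aromatic carbon. Bromo enters on the same aromatic carbon that held trifluoromethyl, part of a fused system of two rings, ortho to a fused ring.

Going by the values given here, with no measured step for guidance, the expectation for compound 3 is a step in this assay of a 1.9-fold higher number from compound 2 to compound 3 (0.28 log units; within the scatter), toward a somewhat higher minimum effective dose but not clearly beyond the scatter. Compound 3 is thus estimated at 0.3 mg/kg, within 0.1 mg/kg to 1 mg/kg.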

Compound 3, minimum effective dose: > 5 mg/kg
Compound 3: only a limit was reported (the forecaster's own chance of this, stated with the estimate: 10%); at least 16-fold (1.22 log units) between middle value and limit.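

In this assay compound 3 is reported only as a limit, (> 5 mg/kg), and not as a number. Even so, the step (an at least 32-fold higher number from compound 2 to compound 3 (1.50 log units; beyond the scatter)) is the first measured change at a single place in this series, and it shows that this aromatic carbon is not indifferent to the group it carries: with the rest of the structure kept, bromo does not stand in for trifluoromethyl in this whole-animal read-out. No measurement shown speaks to the cause of this step.

Going by these compounds, it remains open whether the loss is particular to bromo or whether another group on this carbon, such as chloro, methoxy or nitrile, could come close to the value of compound 2 (0.156 mg/kg). On these data alone, the full size of the step also remains open, since the actual minimum effective dose of compound 3 is not given, and a single change at one position cannot show how far the result extends to other positions on the shared core.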